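The compounds below may be only part of what the source reports. "The series", "measured", "known", "first", "only" and "open" are said of these compounds alone.

In a functional assay on ECa-109 cells for inhibition, with ECa-109 cell line (Homo sapiens) as the target, read by sulforhodamine B assay (a lower number here means a stronger inhibitor, a higher number a weaker inhibitor), compound 2 `O=C1C(N2CCC2)=CC(=O)c2c1nc1n2[C@H]2OC[C@@H](O)[C@H]2OC1` gives > 16000 nM, which is a limit and not a number. Compound 1 `CCc1ccc(NC2=CC(=O)c3c(nc4n3[C@H]3OC[C@@H](O)[C@H]3OC4)C2=O)cc1` gives > 4000 nM, also a limit. Within the data shown here, the one measured step, a step that the two limits leave unreadable from compound 1 to compound 2, therefore has no readable size. Compound 3 `COc1cccc(NC2=CC(=O)c3c(nc4n3[C@H]3OC[C@@H](O)[C@H]3OC4)C2=O)c1` carries (3-methoxyphenyl)amino in place of azetidin-1-yl on a double-bonded ring carbon. Its phenylamino type of group matches compound 1, so the nearest guide is compound 1 at > 4000 nM, again only a limit. The expected change is an at least 2.6-fold lower number from compound 2 to compound 3 (0.42 log units; beyond the scatter), tentatively towards stronger inhibition, and it may be reported only as a limit. For compound 3 the estimate is 6000 nM, with an expected range of 1500 nM to 25000 nM.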

Compound 3, half-maximal inhibitory concentration: 3340 nM
Compound 3: the middle estimate sits 1.8-fold (0.25 log units) above what was measured, within the range that was stated.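

In this assay, among these compounds, the swap at this double-bonded ring carbon gives an at least 4.7-fold lower number from compound 2 to compound 3 (0.68 log units; beyond the scatter) as the first step here with a readable size. Changing the aryl group on the amine nitrogen gives an at least 1.1-fold lower number from compound 1 to compound 3 (0.07 log units; that floor lies within the scatter) and so shows no real difference between those two compounds. The first size is only a floor because compound 2 carries a limit: the limit of > 16000 nM in this assay, at which 1 of the 3 values shown sits. Still open, as far as these compounds go, is whether a plain alkylamino group, such as butylamino, would also give a lower number than azetidin-1-yl. From the compounds shown here alone, how a chloro group or a carboxylic acid on the phenyl ring would read also remains open.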